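Flipping the stereocentre: compound 4 against its measured relatives

A few compounds are considered here, and "the series" means these few. Any claim that something is new, unique, unknown or untested is made for them only; others in the source may bear on it.

Three compounds share one core and differ only in the group on the carbonyl carbon. Compound 1 `O=C([C@H]1CC2CCC1C2)N1CC(c2nc(-c3cccc(F)c3)no2)C1` gives 72 nM in an assay on HEK293 cells for positive allosteric modulation of metabotropic glutamate receptor 5 (Homo sapiens), read by FLIPR; a lower number here means that less compound is needed, a higher number that more compound is needed for the effect. Compound 2 `CC1CCCCC1C(=O)N1CC(c2nc(-c3cccc(F)c3)no2)C1` gives 540 nM in this assay, and compound 3 `Cc1ccc(C(=O)N2CC(c3nc(-c4cccc(F)c4)no3)C2)cc1` gives 6800 nM. Compound 3 therefore has the highest number of the three: the step of a 13-fold higher number from compound 2 to compound 3 (1.10 log units; beyond the scatter) is large, and the step of a 94-fold higher number from compound 1 to compound 3 (1.98 log units; beyond the scatter) is larger still.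

Compound 4 `O=C([C@@H]1CC2CCC1C2)N1CC(c2nc(-c3cccc(F)c3)no2)C1` has not yet been measured. Against compound 3 the change is a group of 7 heavy atoms (7 carbon; 2 five-membered non-aromatic rings of carbon only) in place of a group of 7 heavy atoms (7 carbon; one six-membered aromatic ring of carbon only), on a carbonyl carbon. The entering group is the same bicyclic group as in compound 1, with its single defined stereocentre set the other way, so compound 4 is the mirror form of compound 1 at that centre.

The step that bears most directly on this change is a 94-fold higher number from compound 1 to compound 3 (1.98 log units; beyond the scatter), run in reverse; the step of a 13-fold higher number from compound 2 to compound 3 (1.10 log units; beyond the scatter) points the same way, with an aromatic ring giving a higher number than a saturated one. A large move toward a lower number is therefore expected, though a change of stereochemistry can cost potency, so compound 4 is not expected to reach compound 1. For compound 4 the expected step is a 23-fold lower number from compound 3 to compound 4 (1.36 log units; beyond the scatter), and its estimated value is 300 nM, within a range of 60 nM to 2000 nM.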

Compound 4, half-maximal effective concentration: 100 nM
Beside the measured number, compound 4's estimate is 3.0-fold (0.48 log units) above it; low and high end bracket the measured number.
By their numbers in this assay, from the lowest: compounds 1 and 4 (each within the scatter of the next); then compound 2; then compound 3.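

Reversing the drawn stereocentre leaves no difference that can be separated from the scatter in this assay, with a 1.4-fold higher number from compound 1 to compound 4 (0.14 log units; within the scatter). The bicyclic group on the carbonyl carbon keeps its advantage with the centre drawn either way, since both a 68-fold lower number from compound 3 to compound 4 (1.83 log units; beyond the scatter) and a 5.4-fold lower number from compound 2 to compound 4 (0.73 log units; beyond the scatter) are beyond the scatter, so the gain first seen with compound 1 over 4-methylphenyl and 2-methylcyclohexyl is not confined to one drawing of this centre. This reading needs one caution about how the two structures are drawn: the fact that one of compounds 1 and 4 is drawn with a defined configuration and the other without, at the place where they differ.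

The compounds shown leave open what a single form would give with every stereo element of the bicyclic group drawn, so the true dependence on configuration at this position remains unsettled. All the groups shown on the carbonyl carbon are also built of carbon only, so it remains open whether a group containing a ring nitrogen, such as a piperidine, or a ring oxygen, such as a tetrahydropyran, would keep a number as low as that of compound 4.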